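Three Sulfur-Linked Amides and One Untested Swap

This account rests on a few compounds, and the source may have more. Where it says the series, first, only, none or still open, it means among the compounds named here.

Compound 1 `CC(O)(CSc1cc(C(F)(F)F)cc(C(F)(F)F)c1)C(=O)Nc1ccc(S(F)(F)(F)(F)F)cc1`: 17600 nM
Compound 2 `CC(O)(CS(=O)(=O)c1cccc(S(F)(F)(F)(F)F)c1)C(=O)Nc1cccc(S(F)(F)(F)(F)F)c1`: 11700 nM
Compound 3 `CC(O)(CS(=O)(=O)c1cccc(C(F)(F)F)c1)C(=O)Nc1cccc(S(F)(F)(F)(F)F)c1`: 21800 nM

All three values come from a functional assay on LNCaP cells (Homo sapiens) for antiproliferative activity, read by propidium iodide staining, with a stated time of 96 h; a lower number here means a stronger inhibitor, a higher number a weaker inhibitor. Compound 3 lies within the scatter of both other compounds, so the numbers show a single level with no meaningful order.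

The next structure is compound 4 `CC(O)(CS(=O)(=O)c1ccccc1OC(F)(F)F)C(=O)Nc1cccc(S(F)(F)(F)(F)F)c1`, in which 2-(trifluoromethoxy)phenyl stands in place of 3-(trifluoromethyl)phenyl on a sulfonyl sulfur: 2-(trifluoromethoxy)phenyl in place of 3-(trifluoromethyl)phenyl on a sulfonyl sulfur. For the measured compounds named here, no measured step replaces this whole aromatic group, and no measured compound carries the incoming group. The closest evidence is a 1.9-fold higher number from compound 2 to compound 3 (0.27 log units; within the scatter), which concerns a single group on that aromatic ring. It is one step only, so it gives weak support, but it offers no reason to expect a shift beyond the scatter in this assay, and no clear direction.

The expected result is a 1.3-fold lower number from compound 3 to compound 4 (0.11 log units; within the scatter), a step estimated to stay within the scatter. For compound 4 the estimated value is 17000 nM, with an expected range from 7000 nM to 40000 nM.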

Compound 4, half-maximal inhibitory concentration: 9000 nM
Estimate against measurement, compound 4: 1.9-fold (0.28 log units) above; low and high end bracket the measured number.
By their numbers in this assay, from the lowest: compounds 4, 2, 1 and 3 (each within the scatter of the next, the first and the last beyond it).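

In this assay the aromatic group on the sulfonyl sulfur turns out to be able to move the number beyond the scatter: 2-(trifluoromethoxy)phenyl in place of 3-(trifluoromethyl)phenyl gives a 2.4-fold lower number from compound 3 to compound 4 (0.38 log units; beyond the scatter), whereas the earlier change on that ring, a 1.9-fold higher number from compound 2 to compound 3 (0.27 log units; within the scatter), did not. For the compounds shown here, the shift is modest, and compound 4 remains within the scatter of compound 2, so no compound stands clear of all the others. Nothing available accounts for the shift.

Because the incoming group differs from the outgoing one in both its substituent and its name's ring position, the compounds shown cannot separate these two changes. Also open, from the compounds shown here alone, is how a methoxy group or a chlorine atom on that phenyl ring would read in this assay.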